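Dropping the Chloro Group: What to Expect for Compound 3

A few compounds are considered here, and "the series" means these few. Any claim that something is new, unique, unknown or untested is made for them only; others in the source may bear on it.

Compound 1 `COc1ccccc1Nc1nnc(Nc2nc(-c3ccc(Cl)cc3)cs2)s1` and compound 2 `COc1ccc(Nc2nnc(Nc3nc(-c4ccc(Cl)cc4)cs3)s2)cc1` were both tested in a functional assay on the whole organism (strain albino) with Mus musculus as the target, in the maximal electroshock model, with a stated time of 4 h; on this read-out higher numbers stand for an effect only at larger amounts of compound and lower numbers for an effect already at smaller amounts. In this assay compound 1 gives 300 mg/kg, and compound 2 gives 300 mg/kg. Going by the values given here, the only step measured, no change at the digits printed from compound 1 to compound 2 (within the scatter), shows no change, so compound 2 stands level with compound 1. Compound 3 `COc1ccc(Nc2nnc(Nc3nc(-c4ccccc4)cs3)s2)cc1` differs from compound 2 only in hydrogen in place of chloro on an aromatic carbon. Among the compounds with values here, no measured step touches the chlorine, so there is no direct guide. Compound 3 is expected to show no change at the digits printed from compound 2 to compound 3 (within the scatter), a step within the scatter. The estimate for compound 3 is 300 mg/kg, with a range from 150 mg/kg to 600 mg/kg.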

Compound 3, minimum effective dose: 100 mg/kg
For compound 3 the middle estimate is 3.0-fold (0.48 log units) above the measured one; measured number below the stated range.
By their numbers in this assay, from the lowest: compound 3; then compounds 1 and 2 (each within the scatter of the next).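

Moving the methoxy group left the number unchanged, but this change at the other end of the molecule does alter it: in this assay the swap of 4-chlorophenyl to phenyl gives a 3.0-fold lower number from compound 2 to compound 3 (0.48 log units; beyond the scatter), so the effect appears at a smaller amount. The chloro group is therefore not needed for activity in this pair, and this position influences the result. No measurement available here accounts for this difference. As far as these compounds go, it remains open whether fluoro, methyl or an amine at this place would match hydrogen or chloro. From the compounds shown here alone, whether the same swap would give a similar step on compound 1 also remains open.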